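From 6-methoxypyridin-3-yl to 5-methoxypyrazin-2-yl on the shared core

The compounds below may be only part of what the source reports. "The series", "measured", "known", "first", "only" and "open" are said of these compounds alone.

In a functional assay on PANC-1 cells (Homo sapiens), read by microscopy, crystal violet staining and transwell migration, with a stated time of 18 h, in the presence of a further agent that is not named here (on this read-out lower numbers stand for stronger inhibition and higher numbers for weaker inhibition), compound 3 `CCc1nc(-c2ccc(OC)nc2)n(-c2cccc(C(=O)NCCCCc3ccccc3)c2)n1` gives 810 nM, level with compound 2 `CCc1nc(-c2ccc(OC(F)F)cc2)n(-c2cccc(C(=O)NCCCCc3ccccc3)c2)n1` at 830 nM. Compound 1 `COc1ccc(-c2nc(C)nn2-c2cccc(C(=O)NCCCCc3ccc(Br)cc3)c2)cc1` reads higher at 3020 nM, but it differs from the other two in more than one place, so it offers little guidance here.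

Compound 4 `CCc1nc(-c2cnc(OC)cn2)n(-c2cccc(C(=O)NCCCCc3ccccc3)c2)n1` keeps compound 3 intact except for one group: 5-methoxypyrazin-2-yl in place of 6-methoxypyridin-3-yl on an aromatic carbon. The exchange is 5-methoxypyrazin-2-yl in place of 6-methoxypyridin-3-yl, on an aromatic carbon between two ring nitrogen atoms.

Going by the values given here, only one measured step touches this same place. That step, a 1.0-fold lower number from compound 2 to compound 3 (0.01 log units; within the scatter), put 6-methoxypyridin-3-yl in place of 4-(difluoromethoxy)phenyl and stayed within the scatter. Among the compounds with values here, a single step is thin evidence, and no measured compound carries 5-methoxypyrazin-2-yl, yet nothing here points to a large change in this assay. The expected change is small, a 1.2-fold higher number from compound 3 to compound 4 (0.09 log units; within the scatter), and no step beyond the scatter is expected. For compound 4, the estimated value is 1000 nM, with an expected range of 400 nM to 2500 nM.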

Compound 4, half-maximal inhibitory concentration: 310 nM
Compound 4: the middle estimate sits 3.2-fold (0.51 log units) above what was measured; the whole stated range lies above it.
By their numbers in this assay, from the lowest: compound 4; then compounds 3 and 2 (each within the scatter of the next); then compound 1.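

In this assay, a 2.6-fold lower number from compound 3 to compound 4 (0.42 log units; beyond the scatter) shows that this position, on an aromatic carbon between two ring nitrogen atoms, does respond to the group it carries. The earlier step at this place stayed within the scatter, whereas here a ring with 2 hetero atoms in place of one with 1, with the methoxy group kept, is enough to go beyond it. Compound 4 also parts from the difluoromethoxy compound, with a 2.7-fold lower number from compound 2 to compound 4 (0.43 log units; beyond the scatter), and nothing available here gives a reason for either step.

Going by these compounds, it remains open whether the lower number holds when an ethoxy group or an amine replaces the methoxy group on the 5-methoxypyrazin-2-yl ring. Also open, on these data alone, is whether a pyrimidine ring at this position would read like compound 4 or like compound 3.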